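The compounds below may be only part of what the source reports. "The series", "measured", "known", "first", "only" and "open" are said of these compounds alone.

Measured in a functional assay on T-24 cells (Homo sapiens) for antiproliferative activity, read by sulforhodamine B assay, with a stated time of 72 h; on this read-out higher numbers stand for weaker inhibition and lower numbers for stronger inhibition:
compound 1 `C=CCOC(=O)C1=C2C(=NC1=O)c1cccc3cccc2c13` gives 3900 nM
compound 2 `C=CCOC(=O)C1=C2C(=NC1=O)c1cccc3c(SCCC)ccc2c13` gives 13100 nM
compound 3 `CCCSC(=O)COC(=O)C1=C2C(=NC1=O)c1cccc3cccc2c13` gives 10500 nM

Compound 2 lies within the scatter of compound 3, and both carry higher numbers than compound 1. Compound 4 `CCCSc1ccc2c3c(cccc13)C1=NC(=O)C(C(=O)OCC)=C12` keeps the propylsulfanyl group of compound 2 but has methyl in place of vinyl on a saturated chain carbon bound to an oxygen next to a carbonyl group, that is, ethoxycarbonyl for allyloxycarbonyl: methyl in place of vinyl on a saturated chain carbon bound to an oxygen next to a carbonyl group. Only a 2.7-fold higher number from compound 1 to compound 3 (0.43 log units; beyond the scatter) touches that place, and it was modest despite a much larger replacement. a 3.4-fold higher number from compound 1 to compound 2 (0.53 log units; beyond the scatter) concerns the aromatic carbon, which does not change here. No step beyond the scatter is therefore expected in this assay. The estimated step is a 1.1-fold lower number from compound 2 to compound 4 (0.04 log units; within the scatter). Compound 4 is expected at 12000 nM, within 5500 nM to 26000 nM.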

Compound 4, half-maximal inhibitory concentration: 1700 nM
Estimate against measurement, compound 4: 7.1-fold (0.85 log units) above, and the stated range ends above it.
By their numbers in this assay, from the lowest: compound 4; then compound 1; then compounds 3 and 2 (each within the scatter of the next).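

In this assay, a small change on the saturated chain carbon bound to an oxygen next to a carbonyl group, methyl in place of vinyl, gives a 7.7-fold lower number from compound 2 to compound 4 (0.89 log units; beyond the scatter). That step is larger than a 2.7-fold higher number from compound 1 to compound 3 (0.43 log units; beyond the scatter), which came with a much larger replacement and ran the other way, so this place can move the number in either direction. Nothing available explains the step. On these data alone, it remains open whether methyl in place of vinyl acts alike without the propylsulfanyl group, and how a longer chain, an amine or a carboxylic acid would read here.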